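Chloro-to-nitro swap on a thiosemicarbazone: ortho versus meta

A few compounds are considered here, and "the series" means these few. Any claim that something is new, unique, unknown or untested is made for them only; others in the source may bear on it.

Measured compounds:
- compound 1, `CC1=CC[C@H](C(C)(C)NC(=S)N/N=C/c2ccccc2Cl)CC1`: 700 nM
- compound 2, `CC1=CC[C@H](C(C)(C)NC(=S)N/N=C/c2cccc(Cl)c2)CC1`: 6600 nM
- compound 3, `CC1=CC[C@H](C(C)(C)NC(=S)N/N=C/c2ccccc2[N+](=O)[O-])CC1`: 6400 nM

All three share one core and differ only in the aromatic ring attached to the carbon with a double bond to nitrogen. In a functional assay on PC-3 cells (Homo sapiens) for inhibition, read by sulforhodamine B assay, with a stated time of 48 h (a higher number here means a weaker inhibitor of growth, a lower number a stronger inhibitor of growth), compound 1 gives 700 nM. Moving the chlorine changes the core of compound 1 into that of compound 2, a difference described as 3-chlorophenyl in place of 2-chlorophenyl on a carbon with a double bond to nitrogen; this brings a 9.4-fold higher number from compound 1 to compound 2 (0.97 log units; beyond the scatter). In this assay compound 2 gives 6600 nM. Replacing the chloro of compound 1 by nitro, (nitro in place of chloro on an aromatic carbon), brings a 9.1-fold higher number from compound 1 to compound 3 (0.96 log units; beyond the scatter), so in this assay compound 3 gives 6400 nM. The values of compound 2 and compound 3 lie within the scatter of each other.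

Compound 4, `CC1=CC[C@H](C(C)(C)NC(=S)N/N=C/c2cccc([N+](=O)[O-])c2)CC1`, has not yet been measured. It arises from compound 2 by nitro in place of chloro on an aromatic carbon. Going by the values given here, this is the same kind of change as the one from compound 1 to compound 3, but not the same: there the place was ortho to a large group, here it is meta to a large group. Among the compounds with values here, the one measured example of this swap, a 9.1-fold higher number from compound 1 to compound 3 (0.96 log units; beyond the scatter), weakened growth inhibition; whether the meta place behaves alike is not known from these data. The expected step is therefore a 1.8-fold higher number from compound 2 to compound 4 (0.26 log units; within the scatter), a cautious extension of that single example. In this assay compound 4 is estimated at 12000 nM, with a range from 4000 nM to 40000 nM.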

Compound 4, concentration for total growth inhibition: 88000 nM
Estimate against measurement, compound 4: 7.3-fold (0.87 log units) below, outside the stated range (above it).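

Nitro in place of chloro weakened growth inhibition once more in this assay, this time with a 13-fold higher number from compound 2 to compound 4 (1.12 log units; beyond the scatter). Set beside the earlier example, the two steps agree in direction and in size, so within this series the change carried over from one core to the other without a detectable difference: the same change on two cores in this assay, a 9.1-fold higher number (0.96 log units; beyond the scatter) from compound 1 to compound 3 and a 13-fold higher number (1.12 log units; beyond the scatter) from compound 2 to compound 4, 1.5-fold (0.16 log units) apart, within the scatter of two such steps

Going by these compounds alone, this agreement rests on only two pairs of compounds in a single assay on one cell line, so it shows that the step repeated here, but not that it would repeat on other cores, and it gives no reason why nitro weakens growth inhibition in both pairs.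

The compounds shown carry only chloro or nitro on the aromatic ring, so it remains open whether other groups, such as an amine, a methoxy group or a carboxylic acid, would give numbers closer to those of the chloro compounds or of the nitro compounds. Also open, on these data alone, is how a ring with no added group at all, or with chloro and nitro together, would compare with compound 1 and compound 4.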